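A few compounds are considered here, and "the series" means these few. Any claim that something is new, unique, unknown or untested is made for them only; others in the source may bear on it.

Measured compounds in a functional assay on MOLT-4 cells (Homo sapiens) for cytotoxicity, read by CCK-8 assay, with a stated time of 72 h; on this read-out lower numbers stand for stronger inhibition and higher numbers for weaker inhibition:
compound 1 `C=CCn1c(=O)/c(=C\c2ccccc2Cl)[nH]c(=O)/c1=C\c1ccccc1OC`, 4400 nM
compound 2 `C=CCn1c(=O)/c(=C\c2ccc(Cl)c(Cl)c2)[nH]c(=O)/c1=C\c1ccccc1OC`, "not active" (no number reported)
compound 3 `C=CCn1c(=O)/c(=C\c2ccc(F)c(Br)c2)[nH]c(=O)/c1=C\c1ccccc1OC`, "not active" (no number reported)

Compound 3 stands without a single number in this assay; it is recorded as "not active" (no number reported), and compound 2 is recorded the same way, so compound 1 alone carries a value, 4400 nM. Among the compounds with values here, no step between measured compounds has been computed. Compound 4 `C=CCn1c(=O)/c(=C\c2cc(F)ccc2C)[nH]c(=O)/c1=C\c1ccccc1OC` differs from compound 3 by 5-fluoro-2-methylphenyl in place of 3-bromo-4-fluorophenyl on a double-bonded chain carbon bound to an aromatic carbon. Within the data shown here, with compound 3 giving no number, neither the size nor the direction of the step can be set down from the data; the only anchor is the value of compound 1 with 4400 nM, while compound 2 and compound 3 returned nothing. A weak read-out in this assay is expected for compound 4, estimated at 8000 nM with a range of 2500 nM to 30000 nM, and a fair chance that again only "not active" is reported.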

Compound 4, half-maximal inhibitory concentration: 3800 nM
For compound 4 the middle estimate is 2.1-fold (0.32 log units) above the measured one; the measured number falls inside the stated range.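

In this assay, a second number now stands at this place, on a double-bonded chain carbon bound to an aromatic carbon: 5-fluoro-2-methylphenyl in place of 2-chlorophenyl gives a 1.2-fold lower number from compound 1 to compound 4 (0.06 log units; within the scatter) and the two groups cannot be told apart on this read-out. Compound 4 carries a number where compound 3 carries none, so the steps from the compounds recorded as not active cannot be read. No measurement shown accounts for this difference. Going by these compounds, it remains open whether a carboxylic acid or an amine on this aromatic ring would move the number beyond the scatter.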